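The source may hold more compounds than are shown below. What is called first, only, known or untested is meant among the compounds shown, and "the series" means these compounds.

Three compounds share one core and differ only in the aryl group that sits on a saturated chain carbon bound to a sulfur. Compound 1 `Cn1cc(SCc2nnc(SCc3ccccc3C#N)n2-c2c(Cl)cccc2Cl)c2ccccc21` carries a 2-cyanophenyl there, and in a toxicity assay on HEK-293T cells (Homo sapiens) for cytotoxicity, read by CCK-8 assay, with a stated time of 48 h (on this read-out higher numbers stand for lower toxicity in this test and lower numbers for higher toxicity in this test), compound 1 gives 78600 nM. Compound 2 `Cn1cc(SCc2nnc(SCc3cc(C(F)(F)F)ccc3Cl)n2-c2c(Cl)cccc2Cl)c2ccccc21` carries a 2-chloro-5-(trifluoromethyl)phenyl, and in this assay compound 2 gives 53800 nM. Compound 3 `Cn1cc(SCc2nnc(SCc3cc(Cl)ccc3Cl)n2-c2c(Cl)cccc2Cl)c2ccccc21` carries a 2,5-dichlorophenyl. In this assay, within the data shown here, compound 3 gives > 100000 nM, which is a limit rather than a number, the one such value among the three, as the limit of > 100000 nM in this assay, at which 1 of the 3 values shown sits, shows. So compound 3 stands only at a limit, and none of the three is set apart from the others: a 1.5-fold lower number from compound 1 to compound 2 (0.16 log units; within the scatter), an at least 1.2-fold higher number from compound 1 to compound 3 (0.10 log units; that floor lies within the scatter) and an at least 1.8-fold higher number from compound 2 to compound 3 (0.26 log units; that floor lies within the scatter) all fall within the scatter.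

Compound 4 `Cn1cc(SCc2nnc(SCc3c(F)cccc3Cl)n2-c2c(Cl)cccc2Cl)c2ccccc21` has not yet been measured. It differs from compound 3 in one place: 2-chloro-6-fluorophenyl in place of 2,5-dichlorophenyl on a saturated chain carbon bound to a sulfur. Every step among the measured compounds, each of which exchanged the same aryl group, stayed within the scatter, so no step beyond the scatter is expected in this assay here either. Compound 4 is therefore expected to give 95000 nM in this assay, with a range from 45000 nM to 200000 nM, which means an expected step of an at least 1.0-fold lower number from compound 3 to compound 4 (0.02 log units; that floor lies within the scatter) and a fair chance that the expected value is again only a limit rather than a number.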

Compound 4, half-maximal cytotoxic concentration: > 100000 nM
Compound 4 was reported as a limit; the forecaster's own chance of this, stated with the estimate: 55%; middle value at least 1.0-fold (0.02 log units) away from the limit.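

Compound 4 shows that 2-chloro-6-fluorophenyl on a saturated chain carbon bound to a sulfur also reaches the limit in this assay, as the 2,5-dichlorophenyl of compound 3 did, so the second chlorine of that group is not needed to reach it. The readable comparisons are an at least 1.8-fold higher number from compound 2 to compound 4 (0.26 log units; that floor lies within the scatter) and an at least 1.2-fold higher number from compound 1 to compound 4 (0.10 log units; that floor lies within the scatter), and neither floor sets the newly measured compound apart from the earlier ones. The step from compound 3 to compound 4 cannot be read, and the limit now applies to more of the series than before: the limit of > 100000 nM in this assay, at which 2 of the 4 values shown sit.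

As far as these compounds go, how far compound 3 and compound 4 lie past that limit stays open, so any difference between their two aryl groups remains hidden. Also open is whether an aryl group carrying an amine or a carboxylic acid, or a longer chain in place of the saturated chain carbon, would give a readable number that stands beyond the scatter from the compounds shown here.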